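Ring size of the cyclic amine side chain: compound 1 to compound 4

A few compounds are considered here, and "the series" means these few. Any claim that something is new, unique, unknown or untested is made for them only; others in the source may bear on it.

Values in a functional assay on MOLM-13 cells (Homo sapiens) for inhibition, read by MTT assay, with a stated time of 24 h (a lower number here means a stronger inhibitor, a higher number a weaker inhibitor), for the measured members of the series:
Compound 1 `FC(F)(F)c1cc(NC[C@H]2CCCN2)c2cn[nH]c2c1`: > 20000 nM
Compound 2 `CS(=O)(=O)c1ccc(CNc2cc(C(F)(F)F)cc3[nH]ncc23)c([N+](=O)O)c1`: > 20000 nM
Compound 3 `Cc1ccc(CNc2cc(C(F)(F)F)cc3[nH]ncc23)c([N+](=O)O)c1`: 3430 nM

Compound 1 returns only a limit in this assay, namely (the limit of > 20000 nM in this assay, at which 2 of the 3 values shown sit), so it stands at the weak end of what is shown and carries no number of its own. Compound 2 likewise returns only a limit. For the measured compounds named here, compound 3 is the one member with a measured number.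

Going by the values given here, the single measured step, an at least 5.8-fold lower number from compound 2 to compound 3 (0.76 log units; beyond the scatter), concerns a substituent on an aromatic carbon and leaves untouched the side chain in which compound 1 and compound 4 differ. It therefore gives no guide to the present change.

Compound 4 `FC(F)(F)c1cc(NC[C@@H]2CCCCN2)c2cn[nH]c2c1` differs from compound 1 by piperidin-2-yl in place of pyrrolidin-2-yl on a saturated chain carbon bound to a nitrogen on an aromatic ring. Among the compounds with values here, no measured pair varies this ring, and compound 1 itself offers only a limit, so the step can be read only as a likely direction, not as a size. Compound 4 is expected to remain at or near the limit, estimated at 30000 nM with a range from 6000 nM to 150000 nM. The estimated step, a step that the limit leaves unreadable from compound 1 to compound 4, thus means no change beyond the scatter, and a further limit is the most probable outcome in this assay.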

Compound 4, half-maximal inhibitory concentration: > 20000 nM
Compound 4: no number, only a limit (the forecaster's own chance of this, stated with the estimate: 80%); the middle value does not contradict the limit.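

Compound 1 and compound 4 each return only a limit in this assay, so the step between them cannot be read: the limit of > 20000 nM in this assay, at which 3 of the 4 values shown sit.

The compounds shown leave open whether piperidin-2-yl in place of pyrrolidin-2-yl changes the number in this assay at all, as neither compound carries a measured value.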